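The source may report more compounds than this note shows. Statements on the series, on what has been measured and on what is new or still open speak of the compounds shown alone.

Measured so far in an assay on RBL-1 cells with Polyunsaturated fatty acid 5-lipoxygenase (Rattus norvegicus) as the target; on this read-out lower numbers stand for stronger inhibition and higher numbers for weaker inhibition:
compound 1 `Cn1ccnc1Cc1ccc2ccccc2c1O`, 3500 nM
compound 2 `Oc1c(Cc2cccnc2)ccc2ccccc12`, 230 nM
compound 3 `CC(c1ccccc1)c1ccc2ccccc2c1O`, 70 nM

Compound 2 stands second highest of these three numbers: compound 3 gives a lower value and compound 1 a higher one, both gaps beyond the scatter. Among the compounds with values here, the only single-point step among them runs a 15-fold lower number from compound 1 to compound 2 (1.18 log units; beyond the scatter), a swap of one aromatic ring for another. Compound 4 `O=C(O)CCCCc1ccc2ccccc2c1O` differs from compound 2 by 3-carboxypropyl in place of pyridin-3-yl on a saturated chain carbon bound to an aromatic carbon. Within the data shown here, no measured step exchanges an aromatic ring for an open chain, so that step offers only loose guidance, while the shared core has accepted quite different groups at the same place. For compound 4 a somewhat weaker result is expected, a 2.6-fold higher number from compound 2 to compound 4 (0.42 log units; beyond the scatter). The estimate for compound 4 is 600 nM, between 150 nM and 3000 nM.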

Compound 4, half-maximal inhibitory concentration: 4200 nM
Compound 4: middle estimate off by 7.0-fold (0.85 log units), on the low side, and the stated range ends below it.
By their numbers in this assay, from the lowest: compound 3; then compound 2; then compounds 1 and 4 (each within the scatter of the next).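

In this assay, the open 3-carboxypropyl chain on a saturated chain carbon bound to an aromatic carbon gives up much of what pyridin-3-yl achieves there, with an 18-fold higher number from compound 2 to compound 4 (1.26 log units; beyond the scatter) as the cost of that swap. Against 1-methyl-1H-imidazol-2-yl, the same chain shows a 1.2-fold higher number from compound 1 to compound 4 (0.08 log units; within the scatter) and no real change, so having a ring at this place does not by itself decide the value. No measurement available here explains either result.

The compounds shown do not separate the carboxylic acid from the chain that carries it. A methyl ester or a plain alkyl chain at this place would be needed to tell those two apart.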